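The compounds below may be only part of what the source reports. "The series", "measured", "known", "first", "only" and "open" are said of these compounds alone.

Measured compounds and their values:
Compound 1 `CCCCC[C@@H](C[C@H](O)C[C@@H]1CC=CC(=O)O1)OC` gives 35400 nM in a functional assay on A2780 cells (Homo sapiens) for cytotoxicity, read by MTT assay, with a stated time of 24 h; a higher number here means a weaker inhibitor, a lower number a stronger inhibitor.
Compound 2 `CCCCC[C@@H](CCC[C@H]1CC=CC(=O)O1)OC` gives 20600 nM.
Compound 3 `CCCCC[C@H](C[C@@H](O)C[C@@H]1CC=CC(=O)O1)OC` gives 54500 nM.

Compound 1 holds the second highest of the three numbers, and the values of compound 2 and compound 3 both lie within the scatter of it. The unmeasured compound is compound 4 `CCCCC[C@H](C[C@H](O)C[C@H]1CC=CC(=O)O1)OC`. Against compound 1 the change is a matter of drawing alone: the two compounds have the same atoms and bonds and differ only in configuration as drawn: 2 of 3 stereo elements differ; a stereocentre at a saturated chain carbon is drawn S in compound 1 and R in compound 4; a stereocentre at a saturated ring carbon is drawn S in compound 1 and R in compound 4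

Going by the values given here, one measured step bears on this, a 1.5-fold higher number from compound 1 to compound 3 (0.19 log units; within the scatter), and that step rests on the same kind of change, because of the fact that compounds 1 and 3 differ only in the configuration as drawn. A step of no more than the scatter is therefore expected here, in no particular direction.

Compound 4 is expected to give 36000 nM, with a range of 15000 nM to 85000 nM. That estimate means an expected step of a 1.0-fold higher number from compound 1 to compound 4 (0.01 log units; within the scatter).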

Compound 4, half-maximal inhibitory concentration: 44000 nM
Compound 4: middle estimate off by 1.2-fold (0.09 log units), on the low side, within the range that was stated.
By their numbers in this assay, from the lowest: compounds 2, 1, 4 and 3 (each within the scatter of the next, the first and the last beyond it).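

Going by these compounds alone, this is the first change to reach a saturated ring carbon, which is inverted here together with a saturated chain carbon. In this assay, that gives a 1.2-fold higher number from compound 1 to compound 4 (0.09 log units; within the scatter). The other pair with two inverted centres gives a 1.2-fold lower number from compound 3 to compound 4 (0.09 log units; within the scatter), so neither step involving the ring carbon exceeds the scatter.

On these data alone, the ring carbon never changes alone in these compounds, so its separate contribution remains unknown. Also open, as far as these compounds go, is how a compound with an amine in place of the hydroxyl group would behave in this assay.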